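The source may hold more compounds than are shown below. What is called first, only, known or untested is meant among the compounds shown, and "the series" means these compounds.

Measured so far:
- compound 1, `COc1ccc(Sc2nc3cc(N)cc(N)c3nc2-c2ccccc2)cc1`: < 100000 nM
- compound 2, `Nc1cc(N)c2nc(-c3ccccc3)c(Sc3ccc(Cl)c(Cl)c3)nc2c1`: < 100000 nM

The series shares one core, a diamino-substituted bicyclic aromatic bearing a phenyl and an arylsulfanyl group; the compounds differ only in the aryl on the sulfur. In a functional assay on SF-295 cells (Homo sapiens) for inhibition, read by sulforhodamine B assay, with a stated time of 48 h (on this read-out higher numbers stand for lower toxicity in this test and lower numbers for higher toxicity in this test), compound 1 gives < 100000 nM, which is a limit of the assay and not a number. In this assay compound 2 gives < 100000 nM, again a limit rather than a number. The step that the two limits leave unreadable from compound 1 to compound 2 is therefore unreadable; what the two values show is only that both sit at the limit of < 100000 nM in this assay, at which 2 of the 2 values shown sit.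

Compound 3, `Nc1cc(N)c2nc(-c3ccccc3)c(Sc3ccc(F)cc3)nc2c1`, is not yet measured. It differs from compound 2 as follows: 4-fluorophenyl in place of 3,4-dichlorophenyl on a sulfur. Among the measured compounds shown here, the only measured step on the sulfur aryl, from compound 1 to compound 2, gives no size, so no direction can be taken from it. The working expectation is that compound 3 stays close to the limit region shared by compound 1 and compound 2, and the step that the limit leaves unreadable from compound 2 to compound 3 is estimated as nothing beyond the scatter. Compound 3 is expected at about 40000 nM, with a range from 5000 nM to 100000 nM, and a fair chance that only a limit is reported.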

Compound 3, concentration lethal to 50% of the cells: 64600 nM
Beside the measured number, compound 3's estimate is 1.6-fold (0.21 log units) below it; measured number inside the range.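

The steps from compound 1 and from compound 2 to compound 3 cannot be read in this assay, because the values of compound 1 and compound 2 are limits and not numbers: the limit of < 100000 nM in this assay, at which 2 of the 3 values shown sit.

Going by these compounds, whether 4-fluorophenyl, 3,4-dichlorophenyl and 4-methoxyphenyl on the sulfur differ at all in this assay stays open.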